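Benzyl in Place of Phenyl: Expected Cytotoxicity of Compound 4

The source may hold more compounds than are shown below. What is called first, only, known or untested is meant among the compounds shown, and "the series" means these compounds.

Of the compounds shown here, three built on a shared core have been tested in an ADME assay on MT4 cells (Homo sapiens) for cytotoxicity, read by MTT assay, with a stated time of 96 h; a lower number here means that less compound is tolerated, a higher number that more compound is tolerated. Compound 2 `Cc1ccc(C2CC(c3ccc(Oc4ccccc4)cc3)=NN2c2ccc(S(N)(=O)=O)cc2)cc1` gives 7200 nM. Compound 1 `Cc1ccc(C2CC(c3ccc(OCc4ccccc4)cc3)=NN2c2ccc(S(N)(=O)=O)cc2)cc1` gives 35000 nM in this assay, and compound 3 `NS(=O)(=O)c1ccc(N2N=C(c3ccc(Oc4ccccc4)cc3)CC2c2cccc(Cl)c2)cc1` gives 8000 nM.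

Compound 1 differs from compound 2 by benzyl in place of phenyl on an oxygen on an aromatic ring. That single change made a 4.9-fold higher number from compound 2 to compound 1 (0.69 log units; beyond the scatter), meaning that more of compound 1 was tolerated by the cells. Compound 3 differs from compound 2 by 3-chlorophenyl in place of 4-methylphenyl on a saturated ring carbon, and this is also how the core of compound 3 differs from the core of compound 2. That change gave a 1.1-fold higher number from compound 2 to compound 3 (0.05 log units; within the scatter), a step within the scatter, so the two values cannot be told apart.

Compound 4 `NS(=O)(=O)c1ccc(N2N=C(c3ccc(OCc4ccccc4)cc3)CC2c2cccc(Cl)c2)cc1` has not yet been measured. It differs from compound 3 by benzyl in place of phenyl on an oxygen on an aromatic ring, the same change as from compound 2 to compound 1, at a place described in the same words, although it sits on a core that carries 3-chlorophenyl rather than 4-methylphenyl. Going by the values given here, because that change once gave a 4.9-fold higher number from compound 2 to compound 1 (0.69 log units; beyond the scatter), compound 4 is expected to move from compound 3 by a step of about a 4.4-fold higher number from compound 3 to compound 4 (0.64 log units; beyond the scatter), of similar size to the earlier one, with the single precedent and the different core leaving room for deviation. For compound 4 the estimated value in this assay is 35000 nM, with a likely range from 12000 nM to 90000 nM.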

Compound 4, half-maximal cytotoxic concentration: 36000 nM
Beside the measured number, compound 4's estimate is 1.0-fold (0.01 log units) below it; measured number inside the range.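

In this assay, putting benzyl in place of phenyl on the oxygen gave a 4.5-fold higher number from compound 3 to compound 4 (0.65 log units; beyond the scatter) on the core that carries 3-chlorophenyl, and this step matches the one seen on the core that carries 4-methylphenyl: the same change on two cores in this assay, a 4.9-fold higher number (0.69 log units; beyond the scatter) from compound 2 to compound 1 and a 4.5-fold higher number (0.65 log units; beyond the scatter) from compound 3 to compound 4, 1.1-fold (0.03 log units) apart, within the scatter of two such steps. The other change among these four compounds also reads the same on both sides, with 3-chlorophenyl in place of 4-methylphenyl giving a 1.0-fold higher number from compound 1 to compound 4 (0.01 log units; within the scatter), a step too small to separate the two compounds, and this agrees with the earlier comparison: the same change on two cores in this assay, a 1.1-fold higher number (0.05 log units; within the scatter) from compound 2 to compound 3 and a 1.0-fold higher number (0.01 log units; within the scatter) from compound 1 to compound 4, 1.1-fold (0.03 log units) apart, within the scatter of two such steps. Together these results show that, for compounds 1 to 4, the effects of the two changes can be read independently in this cytotoxicity measure, but this rests on a single set of four compounds and does not show that the phenyl-to-benzyl step would keep its size on any other core.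

The compounds shown leave open whether a longer chain on the oxygen, such as phenylethyl, would continue the trend from phenyl to benzyl. They also leave open how a small group such as methyl would behave there, or whether a fluorine or a nitrile on the benzyl ring would change the step.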